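This account rests on a few compounds, and the source may have more. Where it says the series, first, only, none or still open, it means among the compounds named here.

Working notes on the dichloroacetamide series

All three measured compounds were run in a functional assay on A549 cells (Homo sapiens) for cytotoxicity, read by MTT assay, with a stated time of 68 h; on this read-out higher numbers stand for weaker inhibition and lower numbers for stronger inhibition. Compound 1 `CSc1cccc(-c2cc(NC(=O)C(Cl)Cl)cc(-c3cccc(SC)c3)c2)c1` gives 15900 nM in this assay. Compound 3 `CCOc1cccc(-c2cc(NC(=O)C(Cl)Cl)cc(-c3cccc(OCC)c3)c2)c1` gives 8830 nM in this assay. Compound 2 `O=C(Nc1cccc(-c2nccs2)c1)C(Cl)Cl` reaches only the limit of this assay, > 50000 nM, and no number is known for it. Thus, among the values shown, compound 2 sits at the limit of > 50000 nM in this assay, at which 1 of the 3 values shown sits, while compound 1 and compound 3 sit at numbers that stand for stronger inhibition than that limit; the two numbers themselves lie within the usual scatter of each other.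

Compound 4 `O=C(Nc1cccc(-c2ccccc2)c1)C(Cl)Cl` has not yet been measured in this assay. It differs from compound 2 in one place: phenyl in place of 1,3-thiazol-2-yl on an aromatic carbon. For the measured compounds named here, no pair that differs in one place has been measured, so the size of the step in this assay from compound 2 to compound 4 cannot be read from the data. Since compound 2 only reaches the limit, the expected step is a modest move toward a number, or none beyond the scatter; compound 4 is expected to remain a weak inhibitor, the estimated step being an at least 1.1-fold lower number from compound 2 to compound 4 (0.04 log units; that floor lies within the scatter). Compound 4 is estimated at 45000 nM, within a range from 15000 nM to 120000 nM, with a fair chance that only a limit is reported.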

Compound 4, half-maximal inhibitory concentration: 8900 nM
Compound 4: middle estimate off by 5.1-fold (0.70 log units), on the high side, outside the stated range (below it).
By their numbers in this assay, from the lowest: compounds 3, 4 and 1 (each within the scatter of the next). At a limit, above all of these: compound 2.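

In this assay, this position on the aromatic carbon gives the series its first readable change between two compounds that differ in one place: phenyl in place of 1,3-thiazol-2-yl gives an at least 5.6-fold lower number from compound 2 to compound 4 (0.74 log units; beyond the scatter). The earlier compounds shown here included no such pair, so they could not show that the ring at this position matters for the read-out; this step does show it, as compound 4 gives a measured number of 8900 nM. The step can be stated only as a floor, and its full size cannot be read, because compound 2 is held at a limit of the assay and not at a number: the limit of > 50000 nM in this assay, at which 1 of the 4 values shown sits.

The compounds shown do not tell whether the step depends on the phenyl ring alone, or whether a pyridyl ring, an amine or a carboxylic acid at the same place would give a similar number. They also leave open how much the dichloroacetamide contributes, since no plain acetamide stands beside compound 4 for comparison.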